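Pyrrolidine in place of the distal phenyl of compound 1

The compounds below may be only part of what the source reports. "The series", "measured", "known", "first", "only" and "open" are said of these compounds alone.

Compound 1 `O=[N+]([O-])c1ccc2[nH]c(-c3ccc(-c4ccccc4)cc3)nc2c1` gives 4880 nM in a functional assay for antagonist activity at Neuropeptides B/W receptor type 1 (Homo sapiens), read by cAMP accumulation (a lower number here means a stronger inhibitor, a higher number a weaker inhibitor), the highest of the three numbers measured; compound 3 `Cn1cc(-c2ccc(-c3nc4cc(C(F)(F)F)ccc4[nH]3)cc2)cn1` gives 1470 nM and compound 2 `FC(F)(F)c1ccc2[nH]c(-c3ccc(-c4c[nH]nc4C(F)(F)F)cc3)nc2c1` gives 1200 nM, both beyond the scatter below it. For the measured compounds named here, the only single-point step measured, a 1.2-fold higher number from compound 2 to compound 3 (0.09 log units; within the scatter), puts 1-methyl-1H-pyrazol-4-yl in place of 3-(trifluoromethyl)-1H-pyrazol-4-yl and does not touch the position changed here. Compound 4 `O=[N+]([O-])c1ccc2[nH]c(-c3ccc(N4CCCC4)cc3)nc2c1` differs from compound 1 as follows: pyrrolidin-1-yl in place of phenyl on an aromatic carbon. Phenyl leaves and pyrrolidin-1-yl enters on an aromatic carbon para to a large group. Going by the values given here, no measured step bears on this exchange, so no direction can be read from the series; the step expected in this assay, a 1.2-fold lower number from compound 1 to compound 4 (0.09 log units; within the scatter), is set near nothing with a wide range. Compound 4 is estimated at 4000 nM, between 800 nM and 20000 nM.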

Compound 4, half-maximal inhibitory concentration: 1810 nM
The estimate for compound 4 lay 2.2-fold (0.34 log units) above the measured number; the range from low to high includes it.
By their numbers in this assay, from the lowest: compounds 2, 3 and 4 (each within the scatter of the next); then compound 1.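

At this aromatic carbon, para to a large group, a saturated ring carrying nitrogen is tolerated in place of an aromatic ring of carbon only: in this assay the exchange gives (a 2.7-fold lower number from compound 1 to compound 4 (0.43 log units; beyond the scatter)), a modest gain. Unlike the earlier exchange between two pyrazolyl groups, this change moves the number beyond the scatter. No evidence at hand gives a cause for this step.

From the compounds shown here alone, it remains open whether morpholine or an open-chain amine such as diethylamino behaves like pyrrolidin-1-yl here. The same exchange is also untested on the trifluoromethyl-bearing core of compound 2.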